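Swapping the hydroxyphenyl of compound 2 for a furan ring

A few compounds are considered here, and "the series" means these few. Any claim that something is new, unique, unknown or untested is made for them only; others in the source may bear on it.

Of the compounds shown here, three sharing one core have been measured in an assay on isolated protein for inhibition of Amine oxidase [flavin-containing] A (Homo sapiens), read by fluorescence; a higher number here means a weaker inhibitor, a lower number a stronger inhibitor. Compound 1 `O=C(/C=C/c1nccs1)c1cc(O)c(O)c([N+](=O)[O-])c1` gives 69600 nM. Compound 2 `O=C(/C=C/c1cccc(O)c1)c1cc(O)c(O)c([N+](=O)[O-])c1` gives 43900 nM, the lowest of the three numbers, though its nearest neighbour compound 3 `N#Cc1cccc(/C=C/C(=O)c2cc(O)c(O)c([N+](=O)[O-])c2)c1` gives 58900 nM, and all three sit within the scatter of one another, so no order among them can be claimed.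

Compound 4 `O=C(/C=C/c1ccco1)c1cc(O)c(O)c([N+](=O)[O-])c1` differs from compound 2 in one place: furan-2-yl in place of 3-hydroxyphenyl on a double-bonded chain carbon bound to a double-bonded chain carbon. The most telling comparison is the step from compound 1 to compound 2, where a five-membered aromatic ring with hetero atoms gave way to the same 3-hydroxyphenyl group; that step was a 1.6-fold lower number from compound 1 to compound 2 (0.20 log units; within the scatter). The step of a 1.3-fold higher number from compound 2 to compound 3 (0.13 log units; within the scatter) also shows that changing the group on the ring attached to the double-bonded chain barely moves this assay. Reversing the first step in kind, with furan-2-yl entering, is therefore expected to produce a step of about a 1.4-fold higher number from compound 2 to compound 4 (0.14 log units; within the scatter), that is, nothing clearly beyond the scatter, perhaps a slightly higher number. Compound 4 is estimated to give 60000 nM in this assay, within a range from 25000 nM to 150000 nM.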

Compound 4, half-maximal inhibitory concentration: 60500 nM
Estimate against measurement, compound 4: 1.0-fold (0.00 log units) below, within the range that was stated.
By their numbers in this assay, from the lowest: compounds 2, 3, 4 and 1 (each within the scatter of the next).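

Replacing 3-hydroxyphenyl, with 7 heavy atoms and 1 hydrogen-bond donor, by furan-2-yl, with 5 heavy atoms and 0 hydrogen-bond donors, leaves this assay within the scatter (a 1.4-fold higher number from compound 2 to compound 4 (0.14 log units; within the scatter)). Furan-2-yl in place of the other five-membered ring, 1,3-thiazol-2-yl, also stays within the scatter (a 1.2-fold lower number from compound 1 to compound 4 (0.06 log units; within the scatter)), so across these four compounds, a six-membered or five-membered aromatic ring at this place gives no readable difference, and neither does the presence or absence of the hydrogen-bond donor on the ring. No supporting measurement is available to explain why these swaps leave the assay number within the scatter.

From the compounds shown here alone, all four compounds carry an aromatic ring on the double-bonded chain carbon, so it remains open whether a non-aromatic group at this place, such as an amine, a carboxylic acid or a longer chain, would move the number beyond the scatter. The four compounds also share the same core, so they cannot show how much the nitro and hydroxy groups on it contribute to the numbers seen here.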